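The source may hold more compounds than are shown below. What is called first, only, known or untested is meant among the compounds shown, and "the series" means these compounds.

Compound 1 `O=C1/C(=C\c2ccc(Cl)cc2)S/C(=N/c2ccccc2)N1Cc1ccncc1`: 28800 nM
Compound 2 `O=C1/C(=C\c2ccc(O)c(O)c2)S/C(=N/c2ccccc2)N1Cc1ccncc1`: 16200 nM
Compound 3 `COc1cc(/C=C2/S/C(=N/c3ccccc3)N(Cc3ccncc3)C2=O)ccc1O`: 28600 nM

These values come from a functional assay on HepG2 cells (Homo sapiens) for cytotoxicity, read by MTT assay, with a stated time of 48 h; on this read-out higher numbers stand for weaker inhibition and lower numbers for stronger inhibition. Compound 3, at 28600 nM, cannot be told apart from the other two compounds, as every step among them lies within the scatter.

Compound 4 `O=C1/C(=C\c2ccccn2)S/C(=N/c2ccccc2)N1Cc1ccncc1` differs from compound 3 in one group: pyridin-2-yl in place of 4-hydroxy-3-methoxyphenyl on a double-bonded chain carbon bound to a double-bonded ring carbon. Pyridin-2-yl enters in place of 4-hydroxy-3-methoxyphenyl, on a double-bonded chain carbon bound to a double-bonded ring carbon.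

Two measured steps changed the group at this same place, and both stayed within the scatter: a 1.8-fold lower number from compound 1 to compound 2 (0.25 log units; within the scatter) and a 1.0-fold lower number from compound 1 to compound 3 (0.00 log units; within the scatter). A smaller edit on that group did the same: a 1.8-fold higher number from compound 2 to compound 3 (0.25 log units; within the scatter). Within the data shown here, none of the measured compounds has a hetero atom in the aromatic ring at this place, so the evidence is indirect and the range must be wide.

No step beyond the scatter is therefore expected in this assay. The expected step is a 1.1-fold lower number from compound 3 to compound 4 (0.06 log units; within the scatter). For compound 4 the estimated value is 25000 nM, with an expected range from 11000 nM to 58000 nM.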

Compound 4, half-maximal inhibitory concentration: 31000 nM
Beside the measured number, compound 4's estimate is 1.2-fold (0.09 log units) below it; measured number inside the range.
By their numbers in this assay, from the lowest: compounds 2, 3, 1 and 4 (each within the scatter of the next).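

In this assay, among these compounds, pyridin-2-yl is the first group on this double-bonded chain carbon with a hetero atom in its aromatic ring, and it gives a 1.1-fold higher number from compound 3 to compound 4 (0.03 log units; within the scatter) as well as a 1.9-fold higher number from compound 2 to compound 4 (0.28 log units; within the scatter) and a 1.1-fold higher number from compound 1 to compound 4 (0.03 log units; within the scatter) with no step beyond the scatter. The swap replaces a carbon-only aromatic ring and removes the hydrogen-bond donor of 4-hydroxy-3-methoxyphenyl, yet the values of these four compounds still cannot be told apart. Across these compounds, then, no aromatic group at this place has moved the number by a readable amount, although four compounds are a small sample.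

As far as these compounds go, whether an amine or a carboxylic acid on this aromatic ring, or a longer chain in its place, would stand apart from these values remains open. Nothing measured here speaks to why the four values lie so close together.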